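This account rests on a few compounds, and the source may have more. Where it says the series, first, only, none or still open, it means among the compounds named here.

Values in a functional assay on MDA-MB-231 cells (Homo sapiens) for antiproliferative activity, read by MTT assay; on this read-out lower numbers stand for stronger inhibition and higher numbers for weaker inhibition:
- compound 1 (`CCCCC/C=C\C/C=C\CCCCCCCc1cc(=O)c2c(O)c(C)c(OCOC)c(C)c2o1`): 16100 nM
- compound 2 (`CC/C=C\C/C=C\C/C=C\CCCCCCCc1cc(=O)c2c(O)cc(OCOC)cc2o1`): 6790 nM
- compound 3 (`CCCCC/C=C\C/C=C\CCCCCCCc1cc(=O)c2c(O)cc(OCOC)c(C)c2o1`): 16100 nM
- compound 4 (`CCCCC/C=C\C/C=C\CCCCCCCc1cc(=O)c2c(O)cc(OCOC)cc2o1`): not yet measured

Compound 1 and compound 3 stand level, with compound 3 at 16100 nM and the pair together holding the highest number of the three. Compound 2 reads lower at 6790 nM and lies beyond the scatter from them.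

The change to compound 4 is hydrogen in place of methyl on an aromatic carbon (hydrogen in place of methyl on an aromatic carbon, ortho to a methoxymethoxy group and para to a hydroxy group).

One measured step is of the same kind, at a different aromatic carbon: no change at the digits printed from compound 1 to compound 3 (within the scatter). Compound 2 also has hydrogen at this place but carries a different chain, so its 6790 nM cannot be read as the effect of this change alone. It does allow a modest lean towards a lower number in this assay.

With only these data, no step beyond the scatter is expected: the estimate is a 1.3-fold lower number from compound 3 to compound 4 (0.13 log units; within the scatter) as the expected size.

Compound 4 is expected at about 12000 nM, within an estimated range of 6000 nM to 22000 nM.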

Compound 4, half-maximal inhibitory concentration: > 87000 nM
Compound 4: only a limit was reported; the forecaster's own chance of this, stated with the estimate: 5%; middle value at least 7.2-fold (0.86 log units) from the limit.
By their numbers in this assay, from the lowest: compound 2; then compounds 1 and 3 (each within the scatter of the next). At a limit, above all of these: compound 4.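

In this assay, the methyl group on the aromatic carbon ortho to a methoxymethoxy group and para to a hydroxy group matters in this series: its replacement by hydrogen gives an at least 5.4-fold higher number from compound 3 to compound 4 (0.73 log units; beyond the scatter), whereas the same kind of replacement at the other aromatic carbon gives no change at the digits printed from compound 1 to compound 3 (within the scatter). The reading for compound 4 is a limit of the assay and not a number, so the steps to it fix only a minimum size: the limit of > 87000 nM in this assay, at which 1 of the 4 values shown sits.

Among these compounds, with hydrogen at this place, the chain also counts, since the one change in chain gives an at least 12-fold higher number from compound 2 to compound 4 (1.10 log units; beyond the scatter), so loss of the methyl group does not lead to the limit with every chain.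

As far as these compounds go, whether an ethyl group, a methoxy group or a fluorine atom at this place would keep the number near that of compound 3 stays open. Also open, from the compounds shown here alone, are the true value of compound 4 and whether a methyl group at this place would shift the number for the chain of compound 2 in either direction.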